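Methyl for trifluoromethyl on two related cores

The source may hold more compounds than are shown below. What is called first, only, known or untested is meant among the compounds shown, and "the series" means these compounds.

Measured compounds:
compound 1 `Nc1nc2cc(C(F)(F)F)ccn2c1-c1ccc(O)cc1`: > 100000 nM
compound 2 `Nc1nc2c(C(F)(F)F)cccn2c1-c1ccc(O)cc1`: > 100000 nM
compound 3 `Cc1ccn2c(-c3ccc(O)cc3)c(N)nc2c1`: > 100000 nM

All three readings in an assay on isolated protein for inhibition of ubiquitin carboxyl-terminal hydrolase 14 (Homo sapiens) (a higher number here means a weaker inhibitor, a lower number a stronger inhibitor), are limits of the assay, not numbers. For compound 1 the reading > 100000 nM is a limit. For compound 2 the reading > 100000 nM is likewise a limit. Going by the values given here, for compound 3 the reading > 100000 nM is again a limit, so the limit of > 100000 nM in this assay, at which 3 of the 3 values shown sit, holds for every value so far.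

The change from compound 1 to compound 3 is methyl in place of trifluoromethyl on an aromatic carbon, and its step in this assay is a step that the two limits leave unreadable from compound 1 to compound 3. Compound 2 shares its atoms with compound 1 joined differently; the difference between the two cores is not broken down here.

Compound 4 `Cc1cccn2c(-c3ccc(O)cc3)c(N)nc12` is not yet measured. It arises from compound 2 by methyl in place of trifluoromethyl on an aromatic carbon, the same kind of change as from compound 1 to compound 3, though the place differs: ortho to a fused ring and two atoms from the ring nitrogen rather than meta to a fused ring and opposite the ring nitrogen. Since the earlier step is unreadable and every value sits at the limit, the expected step from compound 2 to compound 4 is a step that the limit leaves unreadable from compound 2 to compound 4. Compound 4 is expected to give about 150000 nM, most likely again a limit.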

Compound 4, half-maximal inhibitory concentration: > 100000 nM
Compound 4: only a limit was reported; the forecaster's own chance of this, stated with the estimate: 85%; the middle value does not contradict the limit.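

No step can be read from compound 2 to compound 4 in this assay, because both readings are limits of the assay rather than numbers: the limit of > 100000 nM in this assay, at which 4 of the 4 values shown sit.

The compounds shown leave open what methyl in place of trifluoromethyl does to inhibition in this assay, and whether any compound on these cores gives a reading that is a number.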